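Isobutyl for Isopropyl on an Amide-Type Nitrogen

The compounds below may be only part of what the source reports. "The series", "measured", "known", "first", "only" and "open" are said of these compounds alone.

Compound 1 `CCCCNC(=S)N/N=C\c1c[nH]c2ccccc12` — in an ADME assay on KB cells (Homo sapiens) for cytotoxicity, read by MTT assay, with a stated time of 44 h (a lower number here means a stronger inhibitor, a higher number a weaker inhibitor), compound 1 gives > 100000 nM, a limit of the assay.
Compound 2 `CC(C)NC(=S)N/N=C\c1c[nH]c2ccccc12` — in this assay compound 2 gives > 100000 nM, again a limit.
Compound 3 `CN(Cc1ccccc1)C(=S)N/N=C\c1c[nH]c2ccccc12` — in this assay compound 3 gives > 100000 nM, also a limit.

All three measured compounds share one core and differ only in the substituent on the amide-type nitrogen. Compound 2 stands at the limit of the assay, and so do the other two; the step that the two limits leave unreadable from compound 1 to compound 2 therefore cannot be read, because the limit of > 100000 nM in this assay, at which 3 of the 3 values shown sit, is where every value sits. Among the measured compounds shown here, no measured step gives a readable size.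

Compound 4 `CC(C)CNC(=S)N/N=C\c1c[nH]c2ccccc12` extends the chain by one carbon: isobutyl in place of isopropyl on an amide-type nitrogen. For the measured compounds named here, the only change that bears on it, a step that the two limits leave unreadable from compound 1 to compound 2, also swapped one small alkyl for another on the same nitrogen without moving the reading off the limit, so compound 4 is expected to remain there as well, with a step from compound 2 of a step that the limit leaves unreadable from compound 2 to compound 4 that is not expected to exceed the scatter. The estimate for compound 4 is 150000 nM, within 50000 nM to 500000 nM.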

Compound 4, half-maximal inhibitory concentration: > 100000 nM
Compound 4 ended at the assay's limit; the forecaster's own chance of this, stated with the estimate: 85%; the middle value lies beyond the limit too.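

Neither step to compound 4, from compound 1 or from compound 2, can be read, because all the compounds share a single limit: the limit of > 100000 nM in this assay, at which 4 of the 4 values shown sit.

The compounds shown leave open whether any substituent on the amide-type nitrogen can bring the reading off that limit.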